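From Methyl to Vinyl on the Nitrogen Chain

This account rests on a few compounds, and the source may have more. Where it says the series, first, only, none or still open, it means among the compounds named here.

Going by the values given here, compound 1 `CCn1c(SCC(=O)c2ccccc2)nnc1-c1cc(OC)c(OC)c(OC)c1` gives 29% in a functional assay on the whole organism (strain albino) for inhibition, with Rattus norvegicus as the target, read by paw edema, with a stated time of 1 h, at a dose of 0.28 mmol/kg by the oral route (on this read-out lower numbers stand for less inhibition and higher numbers for more inhibition at the one dose given (going by the name of the read-out)), the lowest of the two numbers measured so far. Compound 2 `CCn1c(SCC(=O)c2ccccc2)nnc1-c1ccc(OC)c(OC)c1` gives 42% in this assay. Among the compounds with values here, the only measured step, a number 13 percentage points higher from compound 1 to compound 2 (beyond the scatter), concerns a group on the aromatic ring and not the chain on the aromatic nitrogen. Compound 3 `C=CCn1c(SCC(=O)c2ccccc2)nnc1-c1cc(OC)c(OC)c(OC)c1` differs from compound 1 by vinyl in place of methyl on a saturated chain carbon bound to an aromatic nitrogen. Within the data shown here, no measured step touches this chain, so little change is expected, and compound 3 is estimated at 30%, within a range from 15% to 45%. The expected step of a number 1 percentage points higher from compound 1 to compound 3 (within the scatter) lies within the scatter.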

Compound 3, a percentage reported as inhibition, in the whole organism at one dose (the size of the read-out at that dose, not a potency): 49%
Estimate against measurement, compound 3: 19 percentage points below, and the stated range ends below it.
By their numbers in this assay, from the lowest: compound 1; then compounds 2 and 3 (each within the scatter of the next).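

In this assay, the chain on the aromatic nitrogen proves able to move the read-out: vinyl in place of methyl gives a number 20 percentage points higher from compound 1 to compound 3 (beyond the scatter). Until now, only a change on the aromatic ring had shifted the number, so this position matters too. Nothing available explains why this change raises inhibition. As far as these compounds go, whether the double bond or simply the longer chain is responsible stays open, and a propyl chain at this position would separate the two. How a bulkier benzyl group would fare there is also unknown.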